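The source may hold more compounds than are shown below. What is called first, only, known or untested is meant among the compounds shown, and "the series" means these compounds.

Two compounds have been measured in an assay on isolated protein for inhibition of cathepsin S (Homo sapiens), read by fluorescence; on this read-out lower numbers stand for stronger inhibition and higher numbers for weaker inhibition:
compound 1, `CN1CCC(Cc2ccccc2)(NC(=O)c2cnc(C#N)nc2NCC2CCC3(CC2)CC3)CC1`, gives 2 nM
compound 2, `CN1CCC(Oc2nc(C#N)nc(NCC3CCC4(CC3)CC4)c2C(=O)NCc2ccccc2)CC1`, gives 1 nM

Compound 2 gives the lower of the two numbers, yet compound 1 sits right beside it: the gap between them lies within the scatter of repeated measurements, so the two values show one level of inhibition rather than a ranking. Both molecules share a core carrying a nitrile, a spiro-bicyclic amine and a benzyl group, and differ only in how the piperidine is attached.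

Compound 3, `CN1CCC(COc2nc(C#N)nc(NCC3CCC4(CC3)CC4)c2C(=O)NCc2ccccc2)CC1`, has not yet been measured. It differs from compound 2 in one place: (1-methylpiperidin-4-yl)methyl in place of 1-methylpiperidin-4-yl on an oxygen on an aromatic ring. Everything else stays as in compound 2. For the measured compounds named here, no pair of measured compounds differs in just this way, so there is no measured step to lean on. Lengthening the link between the ring oxygen and the piperidine is a small change, and the expected step from compound 2 to compound 3 is a 3.0-fold higher number from compound 2 to compound 3 (0.48 log units; beyond the scatter), a modest rise in the number that may still fall within the scatter. Compound 3 is therefore expected to give about 3 nM, within a range of 0.7 nM to 15 nM.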

Compound 3, half-maximal inhibitory concentration: < 1 nM
Compound 3 gave a limit, no number (the forecaster's own chance of this, stated with the estimate: 2%); at least 3.0-fold (0.47 log units) between middle value and limit.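

In this assay compound 3 gives < 1 nM, which is a limit of the assay and not a number: the limit of < 1 nM in this assay, at which 1 of the 3 values shown sits.

The step therefore has a direction but no readable size: a number no higher from compound 2 to compound 3 (the limit leaves the size open). For the compounds shown here, this is the first direct look at this position, and it shows that (1-methylpiperidin-4-yl)methyl can take the place of 1-methylpiperidin-4-yl on the oxygen on the aromatic ring without any rise in the number, so the estimated rise did not appear.

The limit leaves open whether the (1-methylpiperidin-4-yl)methoxy group truly strengthens inhibition or simply keeps it at the same level, and a more sensitive read-out would be needed to separate the two. From the compounds shown here alone, it also remains open how much more change this position can take, for example whether a longer chain on the oxygen would hold the number this low, or whether a carboxylic acid or a primary amine at the end of such a chain, in place of the 1-methylpiperidine ring, would do the same.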